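The source may report more compounds than this note shows. Statements on the series, on what has been measured and on what is new or still open speak of the compounds shown alone.

Measured compounds in a functional assay on L1210 cells (Mus musculus) for antiproliferative activity, read by cell counting, with a stated time of 2 days; a lower number here means a stronger inhibitor, a higher number a weaker inhibitor:

compound 1 `COc1ccc(C(=O)c2sc(Nc3ccc(Cl)cc3)nc2N)cc1` gives > 10000 nM
compound 2 `Nc1nc(Nc2ccc(Cl)cc2)sc1C(=O)c1ccccc1` gives > 10000 nM
compound 3 `COc1ccccc1C(=O)c1sc(Nc2ccccc2)nc1N` gives 1100 nM

Two of these three results are limits of the assay rather than numbers. For compound 2 the value is a limit. For compound 1 the value is also a limit. Only compound 3 gives a number, so it is the one point from which a step can be read.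

Compound 2 and compound 1 differ by methoxy in place of hydrogen on an aromatic carbon. The step between them is a step that the two limits leave unreadable from compound 2 to compound 1, and it cannot be read because of the limit of > 10000 nM in this assay, at which 2 of the 3 values shown sit. Compound 3 and compound 2 share no single counted difference; the difference between the two cores is not broken down here.

Compound 4 `COc1ccc(Nc2nc(N)c(C(=O)c3ccccc3OC)s2)cc1` has not been measured. It differs from compound 3 by methoxy in place of hydrogen on an aromatic carbon, the same change as that from compound 2 to compound 1, at a place described in the same words. The earlier occurrence gives no readable size, so the expectation for compound 4 rests on compound 3 alone, with 1100 nM as its anchor, and the step of a 1.4-fold higher number from compound 3 to compound 4 (0.13 log units; within the scatter) is estimated as a small one. The estimate for compound 4 in this assay is 1500 nM, with a range from 400 nM to 6000 nM expected.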

Compound 4, half-maximal inhibitory concentration: 31 nM
For compound 4 the middle estimate is 48-fold (1.68 log units) above the measured one, outside the stated range (below it).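

In this assay, putting methoxy in place of hydrogen on an aromatic carbon, para to a large group, gives a 35-fold lower number from compound 3 to compound 4 (1.55 log units; beyond the scatter), so on the core of compound 3 the change from phenyl to 4-methoxyphenyl has a large effect. This single step is the only readable size for the change, and it shows what the change does on that one core, not that the effect carries from one core to another in this series. The change described in the same words from compound 2 to compound 1 neither supports nor contradicts it, since both results are limits rather than numbers and that step cannot be read: the limit of > 10000 nM in this assay, at which 2 of the 4 values shown sit.

The compounds shown leave open whether the effect belongs to methoxy itself, or whether a hydroxyl, an amine or a longer chain such as ethoxy at the same place would also reach the level of compound 4, at 31 nM in this assay. They also leave open whether the change has any effect on a core that starts from a measurable number other than that of compound 3.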